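A few compounds are considered here, and "the series" means these few. Any claim that something is new, unique, unknown or untested is made for them only; others in the source may bear on it.

Of the compounds shown here, two built on a shared core have been tested in an ADME assay on THP-1 cells (Homo sapiens) for cytotoxicity, read by MTT assay, with a stated time of 72 h; a higher number here means that more compound is needed for the effect, a lower number that less compound is needed. Compound 1 `Cc1cncc(-c2ccc3[nH]c(=O)nc(-c4ccccc4)c3c2)c1` reaches only a limit of the assay, > 50000 nM. Compound 2 `O=c1nc(-c2ccccc2)c2ccc(-c3ccncc3)cc2[nH]1` likewise gives only a limit, > 50000 nM. Within the data shown here, with both readings at a limit, no step between them can be sized. Compound 3 `O=c1nc(-c2ccccc2)c2ccc(-c3ccc(F)cc3)cc2[nH]1` is not yet measured; it differs from compound 2 by 4-fluorophenyl in place of pyridin-4-yl on an aromatic carbon. Among the measured compounds shown here, no measured step covers this change, and a step beyond the usual scatter is not expected. Compound 3 is expected to give 50000 nM, within 20000 nM to 100000 nM. The expected step is a number no higher from compound 2 to compound 3 (the limit leaves the size open).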

Compound 3, half-maximal effective concentration: > 50000 nM
Compound 3 gave a limit, no number; the forecaster's own chance of this, stated with the estimate: 80%; the middle value lies on the limit itself.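

Compound 2 and compound 3 both end at a limit, so no step between them can be read in this assay: the limit of > 50000 nM in this assay, at which 3 of the 3 values shown sit.

The compounds shown leave open what concentration, if any, produces the effect, and whether swapping pyridin-4-yl for 4-fluorophenyl changes it.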